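The compounds below may be only part of what the source reports. "The series", "measured", "known", "first", "only" and "open" are said of these compounds alone.

Measured compounds:
compound 1, `C#CC(=O)N(Cc1ccc(OC)c(O)c1)c1cc(OC)c(OC)c(OC)c1`, 310 nM in a functional assay on HCT-116 cells (Homo sapiens) for inhibition, read by MTT assay, with a stated time of 48 h; a lower number here means a stronger inhibitor, a higher number a weaker inhibitor.
compound 2, `COc1ccc(N(Cc2cc(OC)c(OC)c(OC)c2)C(=O)CCl)cc1O`, 22500 nM in this assay.
compound 3, `COc1cc(NCc2ccc(Br)cc2)cc(OC)c1OC`, reported only as a limit of the assay, > 80000 nM in this assay.

Of the two numbers given, compound 1 has the lowest. The nearest number belongs to compound 2, which sits well beyond the usual scatter from compound 1. For compound 3 the assay gives only a limit, (the limit of > 80000 nM in this assay, at which 1 of the 3 values shown sits), and not a number, so its place relative to the other two cannot be set more closely than that.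

The unmeasured compound 4, `CC/C=C/C(=O)N(Cc1ccc(OC)c(O)c1)c1cc(OC)c(OC)c(OC)c1`, keeps the core of compound 1 and differs from it in one place: but-1-en-1-yl in place of ethynyl on a carbonyl carbon. Within the data shown here, no pair of measured compounds shows this particular change, so no step for it has been observed. The account therefore rests on compound 1 alone as the starting point. A step in the direction of a weaker inhibitor is expected, of a size beyond the usual scatter, though without any measured counterpart it remains uncertain in both directions. On that basis compound 4 is expected to give 2500 nM in this assay, within a range of 500 nM to 15000 nM, which corresponds to an estimated step of an 8.1-fold higher number from compound 1 to compound 4 (0.91 log units; beyond the scatter).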

Compound 4, half-maximal inhibitory concentration: 63 nM
Estimate against measurement, compound 4: 40-fold (1.60 log units) above; measured number outside the range, below it.
By their numbers in this assay, from the lowest: compound 4; then compound 1; then compound 2. At a limit, above all of these: compound 3.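

In this assay, but-1-en-1-yl in place of ethynyl on a carbonyl carbon gives a 4.9-fold lower number from compound 1 to compound 4 (0.69 log units; beyond the scatter) and so shows that the triple bond is not needed for a strong inhibitor on the core of compound 1. Until now, compound 1 was the only compound shown with a chain of this kind at this place, so it could not be told whether that chain could be changed without losing strength; the longer chain with a double bond, carried by compound 4, not only keeps that strength but improves on it. Nothing reported here gives a cause for this step.

From the compounds shown here alone, whether the improvement belongs to the double bond, to the length of the chain or to both stays open, and a saturated butyl chain, a shorter propenyl group or a chain ending in an amine would help to separate these. Among these compounds, whether the same step holds on a different core, or with an aryl group such as phenyl at this place, also remains unsettled, as this single pair is the only evidence for the change.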